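Replacing nitro by amino in compound 3

This account rests on a few compounds, and the source may have more. Where it says the series, first, only, none or still open, it means among the compounds named here.

Compound 3 `COc1cc(NS(=O)(=O)c2ccc(C)cc2[N+](=O)[O-])c2nc(C)ccc2c1` stands at the ceiling of an assay on HUVEC cells for inhibition of transcription factor p65 (Homo sapiens); a higher number here means a larger maximal response, a lower number a smaller maximal response: in this assay compound 3 gives > 90%, which is a limit of the assay and not a number. Compound 1 `COc1cc(NS(=O)(=O)c2ccc(C)cc2[N+](=O)[O-])c2ncccc2c1` also reaches a limit in this assay, giving > 90%. Compound 2 `COc1ccc(S(=O)(=O)Nc2cccc3ccc(C)nc23)c([N+](=O)[O-])c1` gives 78% in this assay. Going by the values given here, the only measured step, a step that the two limits leave unreadable from compound 1 to compound 3, methyl in place of hydrogen on an aromatic carbon, cannot be sized, since both of its values sit at the limit of > 90% in this assay, at which 2 of the 3 values shown sit.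

Compound 4 `COc1cc(NS(=O)(=O)c2ccc(C)cc2N)c2nc(C)ccc2c1` differs from compound 3 by amino in place of nitro on an aromatic carbon. No measured step among these compounds involves amino in place of nitro, so none of them sets the size of this change, and the limit at compound 3 hides how much room it has to fall. The step is therefore estimated as a number at least 5 percentage points lower from compound 3 to compound 4 (that floor lies within the scatter), a modest move downward from the limit. Compound 4 is expected to give 85% in this assay, with a range from 60% to 100%.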

Compound 4, largest response reached (reported as efficacy), in percent of the reference or control that the assay uses: > 90%
Compound 4 was reported as a limit (the forecaster's own chance of this, stated with the estimate: 45%); at least 5 percentage points between middle value and limit.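

In this assay compound 4 gives > 90%, which is a limit and not a number. The step between compound 3 and compound 4 therefore cannot be read, since both compounds sit at this limit: the limit of > 90% in this assay, at which 3 of the 4 values shown sit.

The compounds shown leave open how far amino in place of nitro moves the maximal response, or whether it moves it at all.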